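Working notes on a small thymidylate synthase series

The source may hold more compounds than are shown below. What is called first, only, known or untested is meant among the compounds shown, and "the series" means these compounds.

Measured so far, in an assay on L1210 cells for inhibition of Thymidylate synthase (Mus musculus); on this read-out higher numbers stand for weaker inhibition and lower numbers for stronger inhibition:
compound 1 `Cc1cn([C@H]2C[C@H](O)[C@@H](OP(=O)(O)O)O2)c(=O)[nH]c1=O` gives 138000000 nM
compound 2 `O=Cc1cn([C@H]2C[C@H](O)[C@@H](OP(=O)(O)O)O2)c(=O)[nH]c1=O` gives 16200000 nM
compound 3 `O=c1[nH]c(=O)n([C@H]2C[C@H](O)[C@@H](OP(=O)(O)O)O2)cc1CO` gives 269000000 nM

Compound 2 stands lowest of the three numbers. Its nearest neighbour is compound 1, as shown by an 8.5-fold lower number from compound 1 to compound 2 (0.93 log units; beyond the scatter); the furthest is compound 3, as shown by a 17-fold higher number from compound 2 to compound 3 (1.22 log units; beyond the scatter). The gap a 1.9-fold higher number from compound 1 to compound 3 (0.29 log units; within the scatter) lies within the scatter, so compound 1 and compound 3 cannot be ordered against each other.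

Compound 4 `O=c1[nH]c(=O)n([C@H]2C[C@H](O)[C@@H](OP(=O)(O)O)O2)cc1O` is not yet measured. It differs from compound 2 in one place: hydroxy in place of formyl on an aromatic carbon. Within the data shown here, two measured steps bear on this change, since both compound 1 and compound 3 also lack the formyl of compound 2: the step of an 8.5-fold lower number from compound 1 to compound 2 (0.93 log units; beyond the scatter) is modest, the step of a 17-fold higher number from compound 2 to compound 3 (1.22 log units; beyond the scatter) is large. Among the measured compounds shown here, every measured compound without the formyl sits well above compound 2 in this assay, and nothing among the measured compounds suggests compound 4 would break this. A clear rise in the number is therefore expected, beyond the scatter, of a size between the two measured steps.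

Compound 4 is expected to give about 150000000 nM in this assay, plausibly between 30000000 nM and 600000000 nM, which means an expected step of a 9.3-fold higher number from compound 2 to compound 4 (0.97 log units; beyond the scatter).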

Compound 4, inhibition constant: 309000000 nM
For compound 4 the middle estimate is 2.1-fold (0.31 log units) below the measured one; the measured number falls inside the stated range.
By their numbers in this assay, from the lowest: compound 2; then compounds 1, 3 and 4 (each within the scatter of the next, the first and the last beyond it).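

In this assay, hydroxy in place of formyl on this aromatic carbon gives a 19-fold higher number from compound 2 to compound 4 (1.28 log units; beyond the scatter), so a group that enters with a hydrogen-bond donor, where formyl has none, also ends well above compound 2, which now stands beyond the scatter from all three compounds without the formyl. Hydroxy and hydroxymethyl cannot be told apart at this position, as a 1.1-fold higher number from compound 3 to compound 4 (0.06 log units; within the scatter) shows, so the change from the one group to the other has no readable effect on this read-out. Hydroxy in place of methyl gives a 2.2-fold higher number from compound 1 to compound 4 (0.35 log units; beyond the scatter), a modest step and the only one among the compounds without the formyl that lies beyond the scatter, which makes the formyl the one group here with a large separation from the rest.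

The data at hand offer no measured explanation for this separation.

Still open is whether any other group on this aromatic carbon would stay as low as the formyl, since the compounds shown include no acetyl, carboxylic acid, amine or longer chain here. Also open, as far as these compounds go, is whether the standing of the formyl would hold with any change elsewhere on the shared core, which is the same in all four compounds.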